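Hydroxyphenyl Positional Isomers in a HeLa Cytotoxicity Series

The compounds below may be only part of what the source reports. "The series", "measured", "known", "first", "only" and "open" are said of these compounds alone.

Compound 1 `Oc1ccc(-c2cc(-c3ccco3)cc(-c3ccccc3O)n2)cc1` gives > 50000 nM in a functional assay on HeLa cells (Homo sapiens) for cytotoxicity, read by CCK-8 assay; on this read-out lower numbers stand for stronger inhibition and higher numbers for weaker inhibition.
Compound 2 `Oc1ccccc1-c1cc(-c2cccnc2)cc(-c2ccccc2O)n1` gives > 50000 nM in this assay.

Both values are limits of the assay rather than numbers. Compound 2 sits at the limit > 50000 nM in this assay, so its standing among the two values shown is only that it is not resolved from the other one. Compound 1 sits at the same limit, and the shared picture is described by the limit of > 50000 nM in this assay, at which 2 of the 2 values shown sit.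

Compound 3 `Oc1ccc(-c2cc(-c3cccnc3)cc(-c3ccccc3O)n2)cc1` has not yet been measured in this assay. It differs from compound 2 only in that 4-hydroxyphenyl in place of 2-hydroxyphenyl on an aromatic carbon: the two have the same atoms, joined differently, with 4-hydroxyphenyl in place of 2-hydroxyphenyl on an aromatic carbon. Within the data shown here, no step between measured compounds is available, so the size of the change cannot be read from data. Given that compound 2 sits at > 50000 nM and compound 1, which already carries a 4-hydroxyphenyl group, also sits at a limit, the expectation is a step of no size beyond the scatter, that is a number no higher from compound 2 to compound 3 (the limit leaves the size open). Compound 3 is therefore estimated at 50000 nM, within 20000 nM to 100000 nM, most likely reported again as a limit.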

Compound 3, half-maximal inhibitory concentration: > 50000 nM
Compound 3 gave a limit, no number (the forecaster's own chance of this, stated with the estimate: 80%); the middle value sits exactly at the limit.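

In this assay compound 3 gives > 50000 nM, a limit of the assay and not a number. The steps to compound 3 from compound 1 and from compound 2 therefore cannot be read: the limit of > 50000 nM in this assay, at which 3 of the 3 values shown sit.

The compounds shown leave open whether either 4-hydroxyphenyl in place of 2-hydroxyphenyl or pyridin-3-yl in place of furan-2-yl changes the half-maximal inhibitory concentration at all.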